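Swapping the trimethoxyphenyl end of a chalcone for phenyl

A few compounds are considered here, and "the series" means these few. Any claim that something is new, unique, unknown or untested is made for them only; others in the source may bear on it.

Measured compounds:
- compound 1, `COc1cc(/C=C/C(=O)c2cc(-c3cc(OC)c(OC)c(OC)c3)n3nc(-c4ccccc4)cc3n2)cc(OC)c1OC`: 18400 nM
- compound 2, `COc1ccc(-c2cc(/C=C/C(=O)c3ccccc3)nc3cc(-c4ccccc4)nn23)cc1OC`: 11800 nM

Both compounds were tested in a functional assay on MDA-MB-231 cells (Homo sapiens) for antiproliferative activity, read by MTT assay, with a stated time of 24 h; on this read-out higher numbers stand for weaker inhibition and lower numbers for stronger inhibition. Compound 1 gives 18400 nM, and compound 2 gives 11800 nM. For the measured compounds named here, of these two numbers, the one for compound 1 is the higher, but the gap to compound 2 lies within the usual scatter of repeated measurements, so the two compounds cannot be told apart on this read-out; both are weak inhibitors.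

Compound 3, `COc1cc(-c2cc(C(=O)/C=C/c3ccccc3)nc3cc(-c4ccccc4)nn23)cc(OC)c1OC`, has not yet been measured. It differs from compound 1 in one place: phenyl in place of 3,4,5-trimethoxyphenyl on a double-bonded chain carbon bound to a double-bonded chain carbon. The core and the remaining groups are unchanged.

Going by the values given here, no pair of measured compounds differing in only one place is available, so the effect of this change cannot be read from the data. The two measured numbers are close to each other, and compound 2 carries a phenyl on the chain end in the same way. Compound 3 is therefore expected to land near the measured compounds, with a step of a 1.2-fold lower number from compound 1 to compound 3 (0.09 log units; within the scatter) that is small and could go either way within the scatter. The estimate for compound 3 in this assay is 15000 nM, with a range from 5000 nM to 45000 nM.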

Compound 3, half-maximal inhibitory concentration: 19200 nM
Compound 3: middle estimate off by 1.3-fold (0.11 log units), on the low side; the range from low to high includes it.
By their numbers in this assay, from the lowest: compounds 2, 1 and 3 (each within the scatter of the next).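

In this assay, for the compounds shown here, compounds 1 and 3 form the first pair that differs in only one place, so this change can now be read directly: phenyl in place of 3,4,5-trimethoxyphenyl gives a 1.0-fold higher number from compound 1 to compound 3 (0.02 log units; within the scatter) and leaves the two compounds indistinguishable. At this position on the chain, the group can go from 12 heavy atoms to 6 and from 3 hydrogen-bond acceptors to 0 with no difference that this read-out can detect, although both compounds remain weak inhibitors. Nothing available here offers an explanation for this result.

The compounds shown leave open whether the position accepts groups other than these two aromatic rings, such as a ring carrying an amine or a carboxylic acid, or a longer chain in place of the ring. As far as these compounds go, it also remains open whether the same swap would read the same way in another cell line, or on a related compound that inhibits more strongly.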